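A few compounds are considered here, and "the series" means these few. Any claim that something is new, unique, unknown or untested is made for them only; others in the source may bear on it.

Measured so far in a functional assay on A549 cells (Homo sapiens) for antiproliferative activity, read by MTT assay, with a stated time of 48 h; on this read-out higher numbers stand for weaker inhibition and lower numbers for stronger inhibition:
- compound 1 `Cc1ccc(-c2nnc(NC(=O)/C=C/c3ccc(C(F)(F)F)cc3)s2)cc1`: 1.61 ug/mL
- compound 2 `COc1ccc(/C=C/C(=O)Nc2nnc(-c3ccc(C)cc3)s2)cc1`: 0.66 ug/mL
- compound 3 `O=C(/C=C/c1ccc(F)cc1)Nc1nnc(-c2ccccc2)s1`: 1.82 ug/mL

Compound 3 at 1.82 ug/mL lies within the scatter of compound 1, and the number of compound 2 is lower than that of compound 3.

Next in the series is compound 4 `Cc1ccc(-c2nnc(NC(=O)/C=C/c3ccc(F)cc3)s2)cc1`. The change is methyl in place of hydrogen on an aromatic carbon, or phenyl to 4-methylphenyl.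

For the measured compounds named here, no measured step isolates this change. The only one available, a 2.4-fold lower number from compound 1 to compound 2 (0.39 log units; beyond the scatter), is modest and concerns a different place, methoxy in place of trifluoromethyl. It shows only that the series can move beyond the scatter with a single change. Compound 1 and compound 2 both carry the 4-methylphenyl group, and their values bracket a plausible range for compound 4.

A small step is therefore expected, with the estimate at a 1.3-fold lower number from compound 3 to compound 4 (0.11 log units; within the scatter), not beyond the scatter. For compound 4 the estimated value is 1.4 ug/mL, with an expected range of 0.7 ug/mL to 2.8 ug/mL.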

Compound 4, half-maximal inhibitory concentration: 1.23 ug/mL
For compound 4 the middle estimate is 1.1-fold (0.06 log units) above the measured one, and the stated range covers the measured number.
By their numbers in this assay, from the lowest: compounds 2, 4, 1 and 3 (each within the scatter of the next, the first and the last beyond it).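

For the compounds shown here, the step of a 1.5-fold lower number from compound 3 to compound 4 (0.17 log units; within the scatter) in this assay is the first direct reading of methyl in place of hydrogen on an aromatic carbon, and it stays within the scatter for this phenyl to 4-methylphenyl change. With 4-methylphenyl held fixed, the steps of a 1.9-fold higher number from compound 2 to compound 4 (0.27 log units; within the scatter) and a 1.3-fold lower number from compound 1 to compound 4 (0.12 log units; within the scatter) also stay within the scatter, so fluoro is not separated from methoxy or from trifluoromethyl, even though the step of a 2.4-fold lower number from compound 1 to compound 2 (0.39 log units; beyond the scatter) separates those two groups from each other. Nothing at hand bears on why these steps fall as they do.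

Still open, as far as these compounds go, is whether an ethyl group, an amine or a carboxylic acid at the methyl place would give a step beyond the scatter. Also open, from the compounds shown here alone, is whether the methyl step reads the same with methoxy in place of fluoro.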